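Adding trifluoromethyl to a compound stuck at the limit

The source may hold more compounds than are shown below. What is called first, only, known or untested is meant among the compounds shown, and "the series" means these compounds.

Measured in a functional assay on MKN-45 cells (Homo sapiens) for inhibition, read by CCK-8 assay, with a stated time of 24 h; a higher number here means a weaker inhibitor, a lower number a stronger inhibitor:
- Compound 1 `O=C1Nc2ccccc2/C1=C/c1ccc(-c2cn(-c3ccc(F)cc3)nn2)cc1`: 16700 nM
- Compound 2 `O=C1Nc2ccccc2/C1=C/c1ccc(-c2cn(-c3ccccc3Cl)nn2)cc1`: > 20000 nM, a limit and not a number
- Compound 3 `O=C1Nc2ccccc2/C1=C/c1ccc(-c2cn(-c3cccc(Cl)c3)nn2)cc1`: > 20000 nM, a limit and not a number

Compound 3 gives no number, only (the limit of > 20000 nM in this assay, at which 2 of the 3 values shown sit). The next compound to be tested is compound 4 `O=C1Nc2ccccc2/C1=C/c1ccc(-c2cn(-c3ccc(Cl)c(C(F)(F)F)c3)nn2)cc1`. It carries 4-chloro-3-(trifluoromethyl)phenyl in place of 3-chlorophenyl on an aromatic nitrogen.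

Three measured steps change the group at this same place. The first is an at least 1.1-fold higher number from compound 1 to compound 2 (0.07 log units; that floor lies within the scatter). The second is an at least 1.1-fold higher number from compound 1 to compound 3 (0.07 log units; that floor lies within the scatter). Exchanging one chlorophenyl for the other gives a step that the two limits leave unreadable from compound 2 to compound 3. None of these steps shows a change beyond the scatter, so they offer no firm size or direction for the new exchange. Among the measured compounds shown here, the only true number belongs to compound 1, at 16700 nM. Compound 2 and compound 3 give only a limit.

In this assay the expected result is a number no higher from compound 3 to compound 4 (the limit leaves the size open), which means no step beyond the scatter is expected. For compound 4 the estimated value is 20000 nM, with an expected range from 9000 nM to 40000 nM.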

Compound 4, half-maximal inhibitory concentration: 8890 nM
Compound 4: middle estimate off by 2.2-fold (0.35 log units), on the high side, outside the stated range (below it).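

In this assay, this position on the aromatic nitrogen now gives a true number instead of a limit: 4-chloro-3-(trifluoromethyl)phenyl brings an at least 2.2-fold lower number from compound 3 to compound 4 (0.35 log units; beyond the scatter), and the same group replacing 2-chlorophenyl brings an at least 2.2-fold lower number from compound 2 to compound 4 (0.35 log units; beyond the scatter). These two steps are floors and not full sizes, because each starts from a compound held at a limit: the limit of > 20000 nM in this assay, at which 2 of the 4 values shown sit. Among the compounds shown here, measured against the only other true number, the change gives a 1.9-fold lower number from compound 1 to compound 4 (0.27 log units; within the scatter), so the clear gain holds against the two chlorophenyl compounds, while compound 4 cannot be separated from compound 1, which carries the smaller 4-fluorophenyl group.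

As far as these compounds go, it remains open which part of the new group matters, since 4-chloro-3-(trifluoromethyl)phenyl differs from 3-chlorophenyl in both the trifluoromethyl group and the place of the chlorine, and a phenyl bearing trifluoromethyl alone would help to separate the two. Also open is how a methoxy group, an amine or a carboxylic acid on this phenyl ring would compare with the halogen-bearing groups shown here.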